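The source may report more compounds than this note shows. Statements on the series, on what has been measured and on what is new or still open speak of the compounds shown alone.

Measured in an assay on isolated protein for inhibition of Rho-associated protein kinase 1 (Homo sapiens); on this read-out lower numbers stand for stronger inhibition and higher numbers for weaker inhibition:
- compound 1 `COc1cccc(CN(C)C(=O)c2cc3ccc(-c4cn[nH]c4)cc3[nH]2)c1` gives 37 nM
- compound 2 `COc1cccc(CN(C(=O)c2c[nH]c3nc(-c4cn[nH]c4)ccc23)C2CC2)c1` gives 30 nM
- compound 3 `COc1cccc(CN(CCCN(C)C)C(=O)c2cn(C)c3cc(-c4cn[nH]c4)ccc23)c1` gives 13 nM

Compound 2 holds the second highest of the three numbers. Against compound 1 its number is within the scatter, so the two cannot be ordered; against compound 3 the gap is beyond the scatter, with compound 3 giving the lower number.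

Compound 4 `COc1cccc(CN(CCCN2CCN(C)CC2)C(=O)c2c[nH]c3nc(-c4cn[nH]c4)ccc23)c1` is not yet measured. It differs from compound 2 in one place: 3-(4-methylpiperazin-1-yl)propyl in place of cyclopropyl on an amide-type nitrogen. Among the measured compounds shown here, no measured step corresponds to this change. Compound 3, which also carries a longer chain on an amide-type nitrogen, gives 13 nM, though compound 3 differs from compound 2 in more than one place. A modest downward step is expected for compound 4, estimated at a 1.5-fold lower number from compound 2 to compound 4 (0.18 log units; within the scatter). The estimate for compound 4 in this assay is 20 nM, in the range 8 nM to 55 nM.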

Compound 4, half-maximal inhibitory concentration: 260 nM
Beside the measured number, compound 4's estimate is 13-fold (1.11 log units) below it; the measured number lies above the stated range.
By their numbers in this assay, from the lowest: compound 3; then compounds 2 and 1 (each within the scatter of the next); then compound 4.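

With the core of compound 2 held fixed, the group on this amide-type nitrogen clearly matters in this assay: 3-(4-methylpiperazin-1-yl)propyl in place of cyclopropyl gives an 8.7-fold higher number from compound 2 to compound 4 (0.94 log units; beyond the scatter). The earlier compounds shown here offered no single-place step at this position, so this is its first direct read, and it points towards weaker inhibition. Nothing available explains the size of this step.

Whether the chain or the terminal ring accounts for the step remains open. A plain propyl group or a 3-(morpholin-4-yl)propyl group at this nitrogen would help separate the two.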